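The source may report more compounds than this note shows. Statements on the series, on what has been measured and on what is new or still open speak of the compounds shown alone.

Measured so far in a functional assay on a cell-free system (plasma, Homo sapiens), with a stated time of 3 min; on this read-out lower numbers stand for stronger inhibition and higher numbers for weaker inhibition:

- compound 1 `O=C(NCc1cc(Cl)ccc1-n1cnnn1)[C@@H]1C[C@@H]2C[C@@H]2N1C(=O)[C@H](O)CC1CC1`: 1700 nM
- compound 2 `O=C(NCc1cc(Cl)ccc1-n1cnnn1)[C@@H]1C[C@@H]2C[C@@H]2N1C(=O)[C@H](O)c1ccccc1F`: 770 nM

Of these two, compound 2 has the lower number, 770 nM, and so the stronger inhibition. Compound 3 `COC(C)(C)[C@@H](O)C(=O)N1[C@H](C(=O)NCc2cc(Cl)ccc2-n2cnnn2)C[C@@H]2C[C@@H]21` has not yet been measured. It differs from compound 2 by 1-methoxy-1-methylethyl in place of 2-fluorophenyl on a saturated chain carbon bound to a carbonyl carbon and an oxygen on a saturated carbon. Among the measured compounds shown here, only one measured step bears on this change: a 2.2-fold lower number from compound 1 to compound 2 (0.34 log units; beyond the scatter), a modest gain on bringing in 2-fluorophenyl in place of cyclopropylmethyl. Compound 3 gives up the same 2-fluorophenyl, so a step of similar modest size towards a higher number is expected in this assay, though a single step is thin evidence. The expected change is a 1.8-fold higher number from compound 2 to compound 3 (0.26 log units; within the scatter). Compound 3 is estimated at 1400 nM, with an expected range of 500 nM to 4000 nM.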

Compound 3, half-maximal inhibitory concentration: 1000 nM
The estimate for compound 3 lay 1.4-fold (0.15 log units) above the measured number; measured number inside the range.
By their numbers in this assay, from the lowest: compounds 2, 3 and 1 (each within the scatter of the next, the first and the last beyond it).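

In this assay the result shows that this saturated chain carbon accepts an open-chain group with no ring: the change to 1-methoxy-1-methylethyl gives a 1.3-fold higher number from compound 2 to compound 3 (0.11 log units; within the scatter). Set against cyclopropylmethyl, the same group gives a 1.7-fold lower number from compound 1 to compound 3 (0.23 log units; within the scatter), so compound 3 cannot be told apart from either neighbour, and only compound 1 and compound 2 remain separated beyond the scatter. Nothing measured here explains why these three groups lie so close together.

The compounds shown leave open whether the methoxy oxygen of compound 3 matters at all, which a tert-butyl group in the same place would test. As far as these compounds go, how an amine or a carboxylic acid on this carbon would read in this assay also remains unknown.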